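A Chloro-to-Hydrogen Step Among Three Inactive Compounds

The source may hold more compounds than are shown below. What is called first, only, known or untested is meant among the compounds shown, and "the series" means these compounds.

Compound 1 `Cc1nnc(SCc2cc(=O)c3ccccc3o2)o1`: > 25000 nM
Compound 2 `Cc1ccc2oc(CSc3nnc(N)s3)cc(=O)c2c1`: > 25000 nM
Compound 3 `Cc1nnc(SCc2cc(=O)c3cc(Cl)ccc3o2)s1`: > 25000 nM

Three compounds sharing a thioether-linked core were examined in a functional assay on HeLa cells (Homo sapiens) for cytotoxicity, read by MTT assay, with a stated time of 72 h; a higher number here means a weaker inhibitor, a lower number a stronger inhibitor. Compound 1 gives > 25000 nM, which is a limit of the assay and not a number. Compound 2 likewise gives > 25000 nM, again a limit. Compound 3 gives > 25000 nM, also a limit. Compound 3 therefore stands where every measured compound stands, at the limit of > 25000 nM in this assay, at which 3 of the 3 values shown sit, and no ordering among the three can be read from these values, since none of them is a number.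

The next compound, compound 4 `Cc1nnc(SCc2cc(=O)c3ccccc3o2)s1`, differs from compound 3 in a single place: hydrogen in place of chloro on an aromatic carbon. Going by the values given here, no step between two measured compounds is available in this set, so there is no measured basis for expecting any movement in this assay. Given that compound 3 sits at the limit of > 25000 nM in this assay, at which 3 of the 3 values shown sit, the step that the limit leaves unreadable from compound 3 to compound 4 is expected to show no change beyond the scatter, with compound 4 most likely reported as a limit as well. For compound 4 the estimate is 50000 nM, with a range from 20000 nM to 150000 nM.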

Compound 4, half-maximal inhibitory concentration: > 25000 nM
Compound 4 was reported as a limit; the forecaster's own chance of this, stated with the estimate: 85%; the middle value lies beyond the limit too.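

Compound 4 was reported as a limit and not a number, so neither its step from compound 3 nor its step from compound 1 can be read: the limit of > 25000 nM in this assay, at which 4 of the 4 values shown sit.

The compounds shown leave open whether hydrogen in place of chloro, or 5-methyl-1,3,4-thiadiazol-2-yl in place of 5-methyl-1,3,4-oxadiazol-2-yl, changes anything in this assay.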